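The source may hold more compounds than are shown below. What is called first, only, known or untested is meant among the compounds shown, and "the series" means these compounds.

Measured so far in a functional assay (Homo sapiens) for inhibition; on this read-out lower numbers stand for stronger inhibition and higher numbers for weaker inhibition:
- compound 1 `CCCCOc1ccccc1C(=O)/C=C/c1cc(OC)cc(OC)c1`: 13000 nM
- compound 2 `COc1cc(/C=C/C(=O)c2cccc(N(C)C)c2)cc(OC)c1`: 5000 nM
- compound 3 `CCCCOc1ccccc1/C=C/C(=O)c1ccc(OC)c(OC)c1OC`: 52000 nM

Compound 3, at 52000 nM, has the highest number of the three, which makes it the weakest inhibitor so far. Compound 4 `COc1ccc(C(=O)/C=C/c2ccccc2F)c(OC)c1OC` differs from it by one change: fluoro in place of butoxy on an aromatic carbon, ortho to a large group (fluoro in place of butoxy on an aromatic carbon). Going by the values given here, no two measured compounds differ in just one place, so nothing here tests this swap directly. With compound 3 at the top of the range, a moderate move towards stronger inhibition in this assay is expected, though the uncertainty is wide. The estimated step is a 2.6-fold lower number from compound 3 to compound 4 (0.41 log units; beyond the scatter). For compound 4 the estimated value is 20000 nM, with an expected range from 6000 nM to 60000 nM.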

Compound 4, half-maximal inhibitory concentration: 11000 nM
Compound 4: middle estimate off by 1.8-fold (0.26 log units), on the high side; low and high end bracket the measured number.
By their numbers in this assay, from the lowest: compound 2; then compounds 4 and 1 (each within the scatter of the next); then compound 3.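

Replacing butoxy with fluoro on this aromatic carbon, ortho to a large group, gives a 4.7-fold lower number from compound 3 to compound 4 (0.67 log units; beyond the scatter) in this assay and so strengthens inhibition. The butoxy chain, with its 5 heavy atoms, is therefore not needed for this level of inhibition, and a single fluorine atom does better here. No available evidence explains this step. On these data alone, it remains open whether a chloro, an amine or a shorter chain such as ethoxy on this carbon would give weaker or stronger inhibition than fluoro.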